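Trimming the Alkoxy Chain of a Sulfonylurea Vasorelaxant

The compounds below may be only part of what the source reports. "The series", "measured", "known", "first", "only" and "open" are said of these compounds alone.

Measured so far:
compound 1, `CC(C)Oc1ccc(Br)cc1C(C)NC(=O)NS(=O)(=O)c1ccccc1`: 143000 nM
compound 2, `Cc1ccc(S(=O)(=O)NC(=O)NC(C)c2cc(Br)ccc2OC(C)C)cc1`: 61800 nM
compound 3, `CC(C)Oc1ccc(Br)cc1C(C)NC(=O)N(C)S(=O)(=O)c1ccccc1`: 32100 nM

Of the compounds shown here, three sharing one core have been tested in a functional assay on thoracic aorta (Rattus norvegicus, strain Wistar), with a stated time of 15 min; on this read-out lower numbers stand for an effect already at smaller amounts and higher numbers for an effect only at larger amounts of compound. Compound 1 stands at the highest of the three numbers: the step of a 2.3-fold lower number from compound 1 to compound 2 (0.36 log units; beyond the scatter) and the step of a 4.5-fold lower number from compound 1 to compound 3 (0.65 log units; beyond the scatter) both lie beyond the scatter, so compound 1 is the weakest of the set.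

Compound 4, `CCOc1ccc(Br)cc1C(C)NC(=O)NS(=O)(=O)c1ccccc1`, has not yet been measured. Compared with compound 1 the change is hydrogen in place of methyl on a saturated chain carbon bound to an oxygen on an aromatic ring and a saturated chain carbon. Neither measured step bears directly on this change: both earlier steps added a methyl, one on an aromatic carbon and one on an amide-type nitrogen, and both lowered the number by a modest amount, whereas here a methyl is removed from the isopropoxy group. Within the data shown here, with no directly related precedent, the expectation is for no step beyond the scatter, with some chance of a slight rise. The expected step from compound 1 is a 1.1-fold higher number from compound 1 to compound 4 (0.05 log units; within the scatter). Compound 4 is therefore estimated at 160000 nM, within a range from 60000 nM to 450000 nM.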

Compound 4, half-maximal effective concentration: > 300000 nM
Compound 4: a limit, no number (the forecaster's own chance of this, stated with the estimate: 10%); at least 1.8-fold (0.27 log units) between middle value and limit.
By their numbers in this assay, from the lowest: compounds 3 and 2 (each within the scatter of the next); then compound 1. At a limit, above all of these: compound 4.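

In this assay compound 4 gives > 300000 nM, which is a limit of the assay and not a number. Trimming isopropoxy to ethoxy brings an at least 2.0-fold higher number from compound 1 to compound 4 (0.32 log units; beyond the scatter), the first change shown that raises the number; the two earlier steps each added a methyl elsewhere on the molecule and lowered it. So the isopropoxy group is a place where losing one methyl weakens the effect, though only the lower end of this step is known: the limit of > 300000 nM in this assay, at which 1 of the 4 values shown sits.

Open, on these data alone, is whether a longer chain here, such as butoxy, or a ring such as cyclopentyloxy, would bring the number down compared with isopropoxy. Also open, as far as these compounds go, is whether a shorter methoxy group would sit at a limit too, and whether the ethoxy change would act the same way on the cores of compound 2 and compound 3.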